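Removing one methoxy from a weak pyrrolyl chalcone inhibitor

A few compounds are considered here, and "the series" means these few. Any claim that something is new, unique, unknown or untested is made for them only; others in the source may bear on it.

Measured so far:
compound 1 `COc1ccc(/C=C/C(=O)c2ccc[nH]2)c(OC)c1`, in an assay for inhibition of cytochrome P450 1A1 (Homo sapiens), read by fluorescence, using microsomes, with a stated time of 10 min (a lower number here means a stronger inhibitor, a higher number a weaker inhibitor), compound 1 gives 11800 nM
compound 2 `O=C(/C=C/c1ccc(Br)cc1)c1ccc[nH]1`, in this assay compound 2 gives > 20000 nM

Two compounds sharing the same core carry a number in this assay. Among the compounds with values here, compound 1 is the only one with a real value; compound 2 reports only a limit of the assay, (the limit of > 20000 nM in this assay, at which 1 of the 2 values shown sits), so no number stands for it. Compound 1 is therefore the sole anchor, and it sits at the weak end of what this assay resolves.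

Compound 3 `COc1ccccc1/C=C/C(=O)c1ccc[nH]1` is not yet measured. It differs from compound 1 by hydrogen in place of methoxy on an aromatic carbon, on the six-membered aromatic ring of carbon only, meta to a methoxy group and para to a group of 9 heavy atoms. Within the data shown here, no measured pair shows the effect of this change, so the expected step has no direct precedent. Given how weak compound 1 already is, the step from compound 1 to compound 3 is expected to be small, likely within the scatter or slightly toward weaker inhibition, a 1.3-fold higher number from compound 1 to compound 3 (0.10 log units; within the scatter). Compound 3 is thus estimated at 15000 nM, with a range from 5000 nM to 45000 nM.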

Compound 3, half-maximal inhibitory concentration: 900 nM
The estimate for compound 3 lay 17-fold (1.22 log units) above the measured number; the measured number lies below the stated range.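

Replacing the methoxy with hydrogen at this place, meta to a methoxy group and para to a group of 9 heavy atoms, has a large effect in this assay: the change gives a 13-fold lower number from compound 1 to compound 3 (1.12 log units; beyond the scatter), well beyond the scatter. The earlier compounds shown here could not show this: the weak reading of compound 1 did not set the level for the shared core, and taking away a single methoxy, with no new heavy atom added, was enough to shift the number this far. Compound 2 offers no second number for comparison, as its reading is only a limit of the assay: the limit of > 20000 nM in this assay, at which 1 of the 3 values shown sits.

The compounds shown leave open whether the gain belongs to hydrogen specifically, or whether a hydroxyl, a fluorine or an ethoxy at this place would read the same way, as only methoxy and hydrogen can be compared here. They also leave open what the remaining methoxy contributes, and nothing shown says why this single change moves the number so far.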